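Flipping one double bond in a low-toxicity pair

The source may hold more compounds than are shown below. What is called first, only, known or untested is meant among the compounds shown, and "the series" means these compounds.

Compound 1 `Nc1ncnc2c1ncn2/C=C1/C[C@H]1[C@H](O)CO` gives 93500 nM
Compound 2 `Nc1ncnc2c1ncn2/C=C1\C[C@H]1[C@@H](O)CO` gives 73000 nM

Among the compounds with values here, both numbers come from an ADME assay on Akata cells (Homo sapiens) for cytotoxicity (a lower number here means that less compound is tolerated, a higher number that more compound is tolerated), and, with only two compounds measured, compound 2 cannot be told apart from compound 1. Within the data shown here, the single measured step is a 1.3-fold lower number from compound 1 to compound 2 (0.11 log units; within the scatter). What separates the pair is given by the fact that compounds 1 and 2 differ only in the configuration as drawn, with both the double bond and a stereocentre on the chain drawn differently.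

The next compound is compound 3 `Nc1ncnc2c1ncn2/C=C1/C[C@H]1[C@@H](O)CO`. Its relation to compound 2 is simple: the two compounds have the same atoms and bonds and differ only in configuration as drawn: 1 of 3 stereo elements differ; a double bond is drawn E in compound 2 and Z in compound 3. It therefore keeps the stereocentre of compound 2 and takes the Z double bond of compound 1.

Because a 1.3-fold lower number from compound 1 to compound 2 (0.11 log units; within the scatter) covers both changes together and stays small, a change in the double bond alone is not expected to move the number much. The two changes have never been measured separately, so they could in principle offset each other, and the range is kept wide. An estimated 1.1-fold higher number from compound 2 to compound 3 (0.05 log units; within the scatter) is expected, meaning no step beyond the scatter. Compound 3 is expected at 82000 nM, with an estimated range from 42000 nM to 160000 nM.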

Compound 3, half-maximal cytotoxic concentration: 61500 nM
For compound 3 the middle estimate is 1.3-fold (0.12 log units) above the measured one, within the range that was stated.
By their numbers in this assay, from the lowest: compounds 3, 2 and 1 (each within the scatter of the next).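

Compound 3 completes the set by separating the two configuration differences that were combined in the first pair. In this assay, the double bond on its own gives a 1.2-fold lower number from compound 2 to compound 3 (0.07 log units; within the scatter), and the stereocentre on the saturated chain carbon on its own gives a 1.5-fold lower number from compound 1 to compound 3 (0.18 log units; within the scatter). Neither difference, taken alone, separates its two compounds beyond the scatter, so the close values of compound 1 and compound 2 do not conceal two large single-element effects that cancel each other, and all three compounds remain indistinguishable here.

From the compounds shown here alone, the third stereo element is drawn the same way in all three compounds, so whether it matters to the tolerated concentration remains open. Also open, going by these compounds, is whether a structural rather than configurational difference at this chain, such as an amine or a carboxylic acid in place of a hydroxyl group, or a longer chain, would give a step beyond the scatter.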